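A few compounds are considered here, and "the series" means these few. Any claim that something is new, unique, unknown or untested is made for them only; others in the source may bear on it.

Three analogues of one shared core have been measured in an assay on blood for inhibition of C-X-C chemokine receptor type 3 (Homo sapiens), with a stated time of 30 min; on this read-out higher numbers stand for weaker inhibition and lower numbers for stronger inhibition. Compound 1 `CCOc1ncc(-c2nc(C(F)(F)F)sc2N2CCN(C(=O)Cn3nc(C)nc3C)[C@H](C)C2)cn1` gives 364 nM, compound 2 `Cc1nc(C)n(CC(=O)N2CCN(c3sc(C(F)(F)F)nc3-c3cnc(OC(C)C)nc3)C[C@H]2C)n1` gives 216 nM, and compound 3 `CCc1ncc(-c2nc(C(F)(F)F)sc2N2CCN(C(=O)Cn3nc(C)nc3C)[C@H](C)C2)cn1` gives 567 nM. Compound 3 stands at the highest number of the three: a 1.6-fold higher number from compound 1 to compound 3 (0.19 log units; within the scatter) is within the scatter, while a 2.6-fold higher number from compound 2 to compound 3 (0.42 log units; beyond the scatter) is a modest step beyond it. Compound 4 `COc1ccc(-c2nc(C(F)(F)F)sc2N2CCN(C(=O)Cn3nc(C)nc3C)[C@H](C)C2)cn1` is not yet measured. It differs from compound 3 by 6-methoxypyridin-3-yl in place of 2-ethylpyrimidin-5-yl on an aromatic carbon. Among the compounds with values here, two measured steps bear on this change, a 1.6-fold higher number from compound 1 to compound 3 (0.19 log units; within the scatter) and a 2.6-fold higher number from compound 2 to compound 3 (0.42 log units; beyond the scatter), both of which exchange an alkoxy group on the aromatic carbon for ethyl and both of which move the number upward, the second beyond the scatter. Within the data shown here, compound 4 brings an alkoxy group back, a methoxy rather than an ethoxy or isopropoxy, and does so on a different aromatic ring; no measured pair addresses that ring exchange, so the ring part of the change is uncharted. On this basis a small lowering of the number is expected, a 1.5-fold lower number from compound 3 to compound 4 (0.17 log units; within the scatter), roughly returning to the region of compound 1. Compound 4 is estimated at 380 nM, with a range of 150 nM to 900 nM.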

Compound 4, half-maximal inhibitory concentration: 1580 nM
Beside the measured number, compound 4's estimate is 4.2-fold (0.62 log units) below it, and the stated range ends below it.
By their numbers in this assay, from the lowest: compounds 2, 1 and 3 (each within the scatter of the next, the first and the last beyond it); then compound 4.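

The exchange at the aromatic carbon next to the ring nitrogen does not behave as a simple return of an alkoxy group: in this assay, a 2.8-fold higher number from compound 3 to compound 4 (0.45 log units; beyond the scatter), so the methoxy-bearing pyridine sits above even the ethyl-bearing pyrimidine. The gap is wider against the alkoxy pyrimidines, with a 4.3-fold higher number from compound 1 to compound 4 (0.64 log units; beyond the scatter) and a 7.3-fold higher number from compound 2 to compound 4 (0.86 log units; beyond the scatter), which shows that an alkoxy group does not by itself keep the number low at this position. Nothing available gives a reason for this rise.

As far as these compounds go, the ring and the alkoxy group change together here, so the share of each in the rise stays open. A methoxy group on the pyrimidine ring and an isopropoxy group on the pyridine ring would separate the two, and an amine on either ring remains an open question.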